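A few compounds are considered here, and "the series" means these few. Any claim that something is new, unique, unknown or untested is made for them only; others in the source may bear on it.

Compound 1 `COc1cc2cc(NC(C)=O)c(=O)oc2cc1OCCOc1no[n+]([O-])c1S(=O)(=O)c1ccccc1` carries an acetylated amine on its core. In a functional assay on HepG2 cells (Homo sapiens) for inhibition, read by MTT assay, with a stated time of 48 h (on this read-out higher numbers stand for weaker inhibition and lower numbers for stronger inhibition), compound 1 gives 4830 nM. Compound 3 `COc1cc2cc(N)c(=O)oc2cc1OCCOc1no[n+]([O-])c1S(=O)(=O)c1ccccc1` differs from it by one change, (hydrogen in place of acetyl on a nitrogen on an aromatic ring), and in this assay compound 3 gives 3060 nM, so the step is a 1.6-fold lower number from compound 1 to compound 3 (0.20 log units; within the scatter). Compound 2 `COc1cc2cc(NC(C)=O)c(=O)oc2cc1OCCCOc1no[n+]([O-])c1S(=O)(=O)c1ccccc1` has a different core from compound 1; the difference between the two cores is not broken down here. In this assay compound 2 gives 2820 nM, a number close to that of compound 3 and of compound 1, with no difference that stands out from the usual spread of repeat measurements.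

Compound 4 `COc1cc2cc(N)c(=O)oc2cc1OCCCOc1no[n+]([O-])c1S(=O)(=O)c1ccccc1` has not been measured yet. It stands to compound 2 as compound 3 stands to compound 1: the change hydrogen in place of acetyl on a nitrogen on an aromatic ring is the same change, made at the same kind of place on the other core. Because a 1.6-fold lower number from compound 1 to compound 3 (0.20 log units; within the scatter) stayed small, the expected step is a 1.4-fold lower number from compound 2 to compound 4 (0.15 log units; within the scatter). The number expected for compound 4 in this assay is 2000 nM, estimated to lie between 1000 nM and 4500 nM.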

Compound 4, half-maximal inhibitory concentration: 2810 nM
Estimate against measurement, compound 4: 1.4-fold (0.15 log units) below, and the stated range covers the measured number.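

In this assay, going from acetamido to amino on the other core gives a 1.0-fold lower number from compound 2 to compound 4 (0.00 log units; within the scatter). Set beside the earlier step, the change behaves alike on both cores, with neither step standing out from repeat measurements: the same change on two cores in this assay, a 1.6-fold lower number (0.20 log units; within the scatter) from compound 1 to compound 3 and a 1.0-fold lower number (0.00 log units; within the scatter) from compound 2 to compound 4, 1.6-fold (0.20 log units) apart, within the scatter of two such steps. Among the compounds shown here, this shows that, on these two cores, removing the acetyl from the nitrogen makes no measurable difference to the read-out, and that the earlier step was a fair guide to the new one; it does not show that the change would stay this small on any other core, and with only two small steps it cannot say why the acetyl matters so little here.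

The compounds shown carry only acetamido or amino on that nitrogen, so a larger amide such as a benzoyl amide, or a methylamine, remains open. Also open, from the compounds shown here alone, is whether a longer chain than that of compound 2 would give a read-out clearly apart from these four.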